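Working notes on cytotoxicity across compounds 1 to 4

This account rests on a few compounds, and the source may have more. Where it says the series, first, only, none or still open, it means among the compounds named here.

Measured compounds:
Compound 1 `C/C1=C/C2=C(CC(C)(C)[C@@H]2O)[C@H](C)CC[C@@H]1O`: in a functional assay on A549 cells (Homo sapiens) for cytotoxicity, read by MTT assay (on this read-out lower numbers stand for stronger inhibition and higher numbers for weaker inhibition), compound 1 reaches only the limit > 10 ug/mL.
Compound 2 `CC1=C[C@@]23CC(C)(C)C[C@@]2(O)[C@H](C)CC[C@@H]1O3`: in this assay compound 2 reaches only the limit > 10 ug/mL.
Compound 3 `CC(=O)CC/C=C(/C)CC1=CC(C)(C)CC1=O`: in this assay compound 3 reaches only the limit > 10 ug/mL.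

Every value shown is a limit rather than a number, and all three sit at the limit of > 10 ug/mL in this assay, at which 3 of the 3 values shown sit; none can be ordered against another, and compound 3 stands with the others at that limit. Compound 4 `C/C(=C/CC[C@H](C)O)CC1=CC(C)(C)CC1=O` differs from compound 3 as follows: 1-hydroxyethyl in place of acetyl on a saturated chain carbon, two bonds along the chain from a double-bonded chain carbon. Among the measured compounds shown here, no measured pair shares this change, so no size can be read from the series. With every value at the limit, the step that the limit leaves unreadable from compound 3 to compound 4 is expected to be none beyond the scatter. Compound 4 is expected at 15 ug/mL, within 6 ug/mL to 40 ug/mL.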

Compound 4, half-maximal inhibitory concentration: > 10 ug/mL
Compound 4: a limit, no number; the forecaster's own chance of this, stated with the estimate: 80%; the middle value does not contradict the limit.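

No step can be read from compound 3 to compound 4, since both values are limits and not numbers: the limit of > 10 ug/mL in this assay, at which 4 of the 4 values shown sit. From the compounds shown here alone, whether 1-hydroxyethyl in place of acetyl changes cytotoxicity, and how compound 1, compound 2, compound 3 and compound 4 rank, stays open.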